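Allyl for isobutyl across ester and amide analogues

The source may report more compounds than this note shows. Statements on the series, on what has been measured and on what is new or still open speak of the compounds shown alone.

Compound 1 `CC(/C=C/CC(C)CCCC(C)C)=C\C(=O)OCC(C)C` gives 7.69 in a physicochemical assay for lipophilicity; a higher number here means a more lipophilic compound, a lower number a more polar compound. Compound 2 `C=CCOC(=O)/C=C(C)/C=C/CC(C)CCCC(C)C` carries vinyl in place of isopropyl on a saturated chain carbon bound to an oxygen next to a carbonyl group and gives 6.73; the step is a number 0.96 log units lower from compound 1 to compound 2 (beyond the scatter). Compound 3 `CC(/C=C/CC(C)CCCC(C)C)=C\C(=O)NCC(C)C` differs from compound 1 by isobutylamino in place of isobutoxy on a carbonyl carbon. Compound 3 gives 6.19, and stands lowest of the three measured values, with a number 1.50 log units lower from compound 1 to compound 3 (beyond the scatter) and a number 0.54 log units lower from compound 2 to compound 3 (beyond the scatter).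

Compound 4 `C=CCNC(=O)/C=C(C)/C=C/CC(C)CCCC(C)C` is not yet measured. It carries vinyl in place of isopropyl on a saturated chain carbon bound to an amide-type nitrogen, the same kind of change as from compound 1 to compound 2, but the place differs: there the saturated chain carbon is bound to an oxygen next to a carbonyl group, here to an amide-type nitrogen. On the core of compound 3 a step of about a number 0.89 log units lower from compound 3 to compound 4 (beyond the scatter) is expected, resting on the earlier a number 0.96 log units lower from compound 1 to compound 2 (beyond the scatter). Compound 4 is therefore estimated at 5.3, between 4.8 and 5.8.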

Compound 4, partition coefficient: 5.23
Beside the measured number, compound 4's estimate is 0.07 log units above it, within the range that was stated.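

In this assay the isobutyl to allyl change gives a number 0.96 log units lower from compound 3 to compound 4 (beyond the scatter) on the amide, the same size as a number 0.96 log units lower from compound 1 to compound 2 (beyond the scatter) on the ester, while the ester to amide change repeats as well, with a number 1.50 log units lower from compound 2 to compound 4 (beyond the scatter) beside a number 1.50 log units lower from compound 1 to compound 3 (beyond the scatter), and the two changes together give a number 2.46 log units lower from compound 1 to compound 4 (beyond the scatter). The change thus carries over between these two cores, but this rests on one set of four compounds and says nothing about any other core. Nothing available explains the match.

Still open, going by these compounds, is whether a propyl or cyclopropylmethyl group in place of allyl would give a step of this size. Also open, on these data alone, is whether the isobutyl to allyl step would hold on a core with a shorter chain or a carboxylic acid.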